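Removing a Methyl From the Phenol Oxygen

The compounds below may be only part of what the source reports. "The series", "measured", "known", "first", "only" and "open" are said of these compounds alone.

Two compounds share the same core. Compound 1 `O=C(Nc1cccc(-n2cc(-c3ccncc3)c(-c3ccc(Cl)c(O)c3)n2)c1)Nc1cccc(C(F)(F)F)c1` and compound 2 `COc1cc(-c2nn(-c3cccc(NC(=O)Nc4ccc(Cl)c(Cl)c4)c3)cc2-c2ccncc2)ccc1Cl` differ from each other in more than one place. In a functional assay on NCI-H460 cells (Homo sapiens) for inhibition, read by sulforhodamine B assay, with a stated time of 48 h (a lower number here means a stronger inhibitor of growth, a higher number a weaker inhibitor of growth), compound 1 gives 1180 nM, and compound 2 gives 1110 nM; these two numbers lie within the scatter of each other, so neither can be called the stronger inhibitor. Compound 3 `O=C(Nc1cccc(-n2cc(-c3ccncc3)c(-c3ccc(Cl)c(O)c3)n2)c1)Nc1ccc(Cl)c(Cl)c1` follows from compound 2 by a single change: hydrogen in place of methyl on an oxygen on an aromatic ring. Within the data shown here, no measured pair shows this change on its own. The step is expected to be small, a 1.1-fold lower number from compound 2 to compound 3 (0.05 log units; within the scatter), nothing beyond the scatter. Compound 3 is therefore expected to give 1000 nM, with a range from 400 nM to 2500 nM.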

Compound 3, concentration for 50% growth inhibition: 993 nM
Compound 3: middle estimate off by 1.0-fold (0.00 log units), on the high side, within the range that was stated.
By their numbers in this assay, from the lowest: compounds 3, 2 and 1 (each within the scatter of the next).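

In this assay the change from methoxy to hydroxy on the 4-chloro-3-methoxyphenyl group can now be read on its own (a 1.1-fold lower number from compound 2 to compound 3 (0.05 log units; within the scatter)), so this oxygen carries either hydrogen or methyl with no change beyond the scatter. Compound 3 also isolates 3,4-dichlorophenyl in place of 3-(trifluoromethyl)phenyl on the amide-type nitrogen (a 1.2-fold lower number from compound 1 to compound 3 (0.07 log units; within the scatter)), and that swap likewise stays within the scatter. No supporting measurement bears on these results.

As far as these compounds go, whether an ethoxy group or an amine at this place would leave the number just as unmoved remains open.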